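The compounds below may be only part of what the source reports. "The series", "measured", "known", "first", "only" and "open" are said of these compounds alone.

Compound 1 `CC(=O)Nc1cccc2c1CCCC2c1c[nH]cn1`: in an assay on isolated protein (Cricetulus griseus) for binding affinity to Alpha-1B adrenergic receptor (Mesocricetus auratus), read by radioligand binding (on this read-out higher numbers stand for weaker inhibition and lower numbers for stronger inhibition), compound 1 gives < 10000 nM, a limit of the assay.
Compound 2 `O=C(Nc1cccc2c1CCCC2c1c[nH]cn1)C(F)(F)F`: in this assay compound 2 gives < 10000 nM, also a limit of the assay.

Compound 2 therefore stands only at the limit of < 10000 nM in this assay, at which 2 of the 2 values shown sit; no number is known for it. For the measured compounds named here, the one measured step, a step that the two limits leave unreadable from compound 1 to compound 2, is unreadable because both ends sit at a limit, so it gives no size in either direction. Compound 3 `COC(=O)Nc1cccc2c1CCCC2c1c[nH]cn1` carries a change in the same place, (methoxy in place of trifluoromethyl on a carbonyl carbon). With no readable step to lean on, compound 3 is expected to give 3000 nM, between 300 nM and 10000 nM, the step that the limit leaves unreadable from compound 2 to compound 3 being an estimate only.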

Compound 3, inhibition constant: 10000 nM
Estimate against measurement, compound 3: 3.3-fold (0.52 log units) below; low and high end bracket the measured number.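

In this assay, for the compounds shown here, compound 3 gives 10000 nM, the first plain number at this position, with methoxy on the carbonyl carbon. The two new steps are a number no lower from compound 2 to compound 3 (the limit leaves the size open) and a number no lower from compound 1 to compound 3 (the limit leaves the size open). Neither step can be read in size, because each starts from a limit: the limit of < 10000 nM in this assay, at which 2 of the 3 values shown sit.

Methyl, trifluoromethyl and methoxy therefore cannot be ranked on this carbonyl carbon.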